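This account rests on a few compounds, and the source may have more. Where it says the series, first, only, none or still open, it means among the compounds named here.

Compound 1 `O=c1ccn(CCOc2ccccc2Oc2cccc3ccccc23)c(=O)[nH]1` and compound 2 `O=c1ccn(CCOc2ccccc2Oc2cccc3cc(Cl)ccc23)c(=O)[nH]1` are built on one core, while compound 3 `N#Cc1cc2c(Oc3ccccc3OCCn3ccc(=O)[nH]c3=O)cccc2o1` and compound 4 `N#Cc1cc2c(Oc3ccc(Cl)cc3OCCn3ccc(=O)[nH]c3=O)cccc2o1` are built on another; the difference between the two cores is not broken down here. All of them were, or will be, tested in an ADME assay on MT2 cells (Homo sapiens) for cytotoxicity, read by MTT assay; a higher number here means that more compound is tolerated, a lower number that less compound is tolerated. In this assay compound 1 gives 80000 nM. Compound 2 reaches only the limit of this assay, recorded as > 100000 nM, which is not a number. Compound 3 likewise reaches only the limit, recorded as > 100000 nM, and no number is known for it.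

Compound 2 differs from compound 1 by chloro in place of hydrogen on an aromatic carbon, and the outcome of that change is an at least 1.2-fold higher number from compound 1 to compound 2 (0.09 log units; that floor lies within the scatter). Compound 4 differs from compound 3 by chloro in place of hydrogen on an aromatic carbon. This is the same kind of change, though not the same change: in compound 2 the chloro sits on a ring that is part of a fused or bridged system of two rings, meta to a fused ring and para to a fused ring, whereas in compound 4 it sits on a six-membered aromatic ring of carbon only, meta to a large group and para to a large group.

The step from compound 3 to compound 4 is expected to be a number no higher from compound 3 to compound 4 (the limit leaves the size open), because an at least 1.2-fold higher number from compound 1 to compound 2 (0.09 log units; that floor lies within the scatter) gave no clear movement and because the limit of > 100000 nM in this assay, at which 2 of the 3 values shown sit, shows where most values already sit. Compound 4 is therefore estimated to give about 100000 nM in this assay, somewhere between 50000 nM and 200000 nM, quite possibly again only as a limit.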

Compound 4, half-maximal cytotoxic concentration: 7000 nM
The estimate for compound 4 lay 14-fold (1.15 log units) above the measured number, outside the stated range (below it).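

In this assay, chloro in place of hydrogen on an aromatic carbon gives an at least 14-fold lower number from compound 3 to compound 4 (1.15 log units; beyond the scatter), so on this core the change leaves far less compound tolerated. Set beside the earlier step, this kind of change did not carry over in the same way from one core to the other: the same change on two cores in this assay, an at least 1.2-fold higher number (0.09 log units; that floor lies within the scatter) from compound 1 to compound 2 and an at least 14-fold lower number (1.15 log units; beyond the scatter) from compound 3 to compound 4, at least 17-fold (1.25 log units) apart, beyond the scatter of two such steps. This does not show why the two steps part, as the chloro sits on a different kind of ring in each pair, and a single pair on each core cannot separate the effect of the core from that of the chloro's place.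

Going by these compounds, it remains open whether chloro on a six-membered aromatic ring of carbon only, meta to a large group and para to a large group, would also lower the number on the core of compound 1, which would help to separate those two explanations. On these data alone, it is also open whether fluoro, methoxy or an amine at that place on the core of compound 3 would lower the number as chloro does, or whether the step seen here belongs to chloro alone.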